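Replacing oxan-4-yl on compound 2

A few compounds are considered here, and "the series" means these few. Any claim that something is new, unique, unknown or untested is made for them only; others in the source may bear on it.

In a functional assay on MDA-MB-231 cells (Homo sapiens) for inhibition, read by MTT assay, with a stated time of 5 days (a lower number here means a stronger inhibitor, a higher number a weaker inhibitor), the measured compounds are as follows:
- Compound 1 `Cc1cc(Nc2nc(NCc3ccc(Cl)cc3)nc3c2cnn3CC(C)(C)O)n[nH]1` gives 3980 nM
- Compound 2 `Cc1cc(Nc2nc(NCc3ccc(F)cc3F)nc3c2cnn3C2CCOCC2)n[nH]1` gives 2880 nM

Compound 2, at 2880 nM on this scale, lies within the usual scatter of compound 1, so the two numbers cannot be ranked. Compound 3 `Cc1cc(Nc2nc(NCc3ccc(F)cc3F)nc3c2cnn3CC(C)(C)O)n[nH]1` keeps everything in compound 2 except one place, where 2-hydroxy-2-methylpropyl takes the place of oxan-4-yl on an aromatic nitrogen (2-hydroxy-2-methylpropyl in place of oxan-4-yl on an aromatic nitrogen).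

Going by the values given here, no measured pair shows this change on its own, so its size in this assay is not known directly. Among the compounds with values here, the only guide is compound 1, which carries 2-hydroxy-2-methylpropyl on that nitrogen and gives 3980 nM as its value, within the scatter of compound 2. Compound 1 also differs from compound 3 elsewhere in the structure, so this guide is loose. The expected change is a 1.1-fold higher number from compound 2 to compound 3 (0.06 log units; within the scatter) and should stay within the scatter, in either direction. In this assay the estimate for compound 3 is 3300 nM (expected range 1400 nM to 7500 nM).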

Compound 3, half-maximal inhibitory concentration: 2510 nM
Compound 3: the middle estimate sits 1.3-fold (0.12 log units) above what was measured; the range from low to high includes it.
By their numbers in this assay, from the lowest: compounds 3, 2 and 1 (each within the scatter of the next).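

In this assay, replacing oxan-4-yl with 2-hydroxy-2-methylpropyl on the aromatic nitrogen gives a 1.1-fold lower number from compound 2 to compound 3 (0.06 log units; within the scatter) and now has a direct reading: the two groups cannot be told apart here, even though a six-membered non-aromatic ring leaves and the count of hydrogen-bond donors goes from 0 to 1. With 2-hydroxy-2-methylpropyl held fixed, placing 2,4-difluorophenyl where 4-chlorophenyl stood gives a 1.6-fold lower number from compound 1 to compound 3 (0.20 log units; within the scatter) and is also within the scatter, so neither of these two changes has a size that can be separated from ordinary assay noise. No supporting measurement is available to explain why these groups read alike.

The compounds shown cover only neutral groups on that nitrogen, so it stays open whether an amine, a carboxylic acid or a longer chain there would move the number beyond the scatter. On these data alone, it is equally open whether a methoxy group or a nitrile on the phenyl ring, in place of the halogens, would produce a step large enough to read.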